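Benzyl in place of methyl on the selenium of compound 3

The source may hold more compounds than are shown below. What is called first, only, known or untested is meant among the compounds shown, and "the series" means these compounds.

Compound 3 `C[Se]/C(=N\C(=O)c1cnc2ccccc2c1)NC(=O)c1cnc2ccccc2c1` is the strongest growth inhibitor of the three measured compounds. In a functional assay on HT-29 cells (Homo sapiens) for cytotoxicity, read by MTT assay, with a stated time of 72 h (a higher number here means a weaker inhibitor of growth, a lower number a stronger inhibitor of growth), compound 3 gives 200 nM, a number far lower than those of compound 1 `CS/C(=N\C(=O)c1ccco1)NC(=O)c1ccco1` at 77100 nM and of compound 2 `CS/C(=N\C(=O)c1cc(-c2ccccc2)nc2ccccc12)NC(=O)c1cc(-c2ccccc2)nc2ccccc12` at 23700 nM, both of which carry sulfur rather than selenium and other aromatic amides. The unmeasured compound 4 `O=C(/N=C(/NC(=O)c1cnc2ccccc2c1)[Se]Cc1ccccc1)c1cnc2ccccc2c1` keeps everything of compound 3 except one change: phenyl in place of hydrogen on a saturated chain carbon bound to a selenium atom. Within the data shown here, no measured pair shows this change, so its effect is unknown. The step from compound 3 to compound 4 is expected to be small, a 2.0-fold higher number from compound 3 to compound 4 (0.30 log units; within the scatter), with a weakening as likely as none beyond the scatter. In this assay compound 4 is estimated at 400 nM, within a range from 80 nM to 2000 nM.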

Compound 4, concentration for 50% growth inhibition: 26100 nM
Estimate against measurement, compound 4: 65-fold (1.81 log units) below; measured number above the stated range.
By their numbers in this assay, from the lowest: compound 3; then compounds 2 and 4 (each within the scatter of the next); then compound 1.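

In this assay, methyl to benzyl on the selenium gives a 130-fold higher number from compound 3 to compound 4 (2.12 log units; beyond the scatter), so this position responds strongly to change. Among these compounds, no earlier pair differed only here, so this is the first direct reading of the position. Nothing at hand bears on why the number rises.

The compounds shown leave open whether a chain shorter than benzyl, such as ethyl, stays near compound 3. Also open, from the compounds shown here alone, is whether a benzyl carrying an amine or a carboxylic acid on its phenyl would behave like compound 4.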